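The source may hold more compounds than are shown below. What is called first, only, known or untested is meant among the compounds shown, and "the series" means these compounds.

Among the measured compounds shown here, in a functional assay on MOLT-4 cells (Homo sapiens) for inhibition, read by sulforhodamine B assay, with a stated time of 48 h (a higher number here means a weaker inhibitor of growth, a lower number a stronger inhibitor of growth), compound 1 `O=C(Cc1csc2nc(-c3ccc(Br)cc3)cn12)N/N=C/c1ccccc1` gives 6760 nM, while compound 2 `O=C(Cc1csc2nc(-c3ccc(Br)cc3)cn12)N/N=C/c1ccccc1O` gives 2340 nM, the lower of the two numbers so far. Compound 3 `O=C(Cc1csc2nc(-c3ccc(Br)cc3)cn12)N/N=C/c1ccc(O)cc1` has the same atoms as compound 2, joined differently: 4-hydroxyphenyl in place of 2-hydroxyphenyl on a carbon with a double bond to nitrogen. It carries 4-hydroxyphenyl in place of 2-hydroxyphenyl on a carbon with a double bond to nitrogen. For the measured compounds named here, the only measured step bearing on this is a 2.9-fold lower number from compound 1 to compound 2 (0.46 log units; beyond the scatter), a modest one, so the expected change is a 1.3-fold higher number from compound 2 to compound 3 (0.11 log units; within the scatter), with no step beyond the scatter anticipated. For compound 3 the estimated value is 3000 nM, with an expected range of 1200 nM to 7000 nM.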

Compound 3, concentration for 50% growth inhibition: 4170 nM
Compound 3: middle estimate off by 1.4-fold (0.14 log units), on the low side; measured number inside the range.
By their numbers in this assay, from the lowest: compounds 2, 3 and 1 (each within the scatter of the next, the first and the last beyond it).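

In this assay, 4-hydroxyphenyl in place of 2-hydroxyphenyl gives a 1.8-fold higher number from compound 2 to compound 3 (0.25 log units; within the scatter), so these two hydroxyphenyl groups cannot be told apart here. With 4-hydroxyphenyl, hydroxy in place of hydrogen gives a 1.6-fold lower number from compound 1 to compound 3 (0.21 log units; within the scatter), so only 2-hydroxyphenyl, not 4-hydroxyphenyl, stands beyond the scatter from the unsubstituted phenyl of compound 1. No available evidence accounts for these steps. Going by these compounds, whether a methoxy group or an amine in place of the hydroxy would give a number clearly apart from compound 1 remains open.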